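The source may hold more compounds than are shown below. What is called first, only, known or untested is meant among the compounds shown, and "the series" means these compounds.

Of the compounds shown here, three built on one shared core have been tested in a functional assay on RXF 393 cells (Homo sapiens) for inhibition, read by sulforhodamine B assay, with a stated time of 48 h; a lower number here means that less compound is tolerated, a higher number that more compound is tolerated. Compound 1 `Nc1cc(N)c2nc(-c3ccccc3)c(Oc3ccc(Cl)c(Cl)c3)nc2c1` gives < 100000 nM, which is a limit of the assay and not a measured number. Compound 2 `CCOC(=O)[C@H](CCC(=O)O)NC(=O)c1ccc(CNc2nc3cc(N)cc(N)c3nc2-c2ccccc2)cc1` likewise gives < 100000 nM, again a limit. Compound 3 `Nc1cc(N)c2nc(-c3ccccc3)c(NCc3ccc(Cl)c(Cl)c3)nc2c1` gives < 100000 nM, also a limit. Compound 3 therefore cannot be placed above or below its neighbours on the numbers shown: every value sits at the same point, (the limit of < 100000 nM in this assay, at which 3 of the 3 values shown sit), and no ordering among the three compounds can be read from it. Among the measured compounds shown here, no step between two measured compounds is given, so no measured change of the read-out is available to lean on.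

Compound 4 `COc1ccc(CNc2nc3cc(N)cc(N)c3nc2-c2ccccc2)cc1OC` differs from compound 3 in one place: 3,4-dimethoxyphenyl in place of 3,4-dichlorophenyl on a saturated chain carbon bound to a nitrogen on an aromatic ring. For the measured compounds named here, for this step in this assay the expectation is a change no larger than the usual scatter, in no set direction, as the only comparison point is a limit. The step from compound 3 to compound 4 is estimated at a step that the limit leaves unreadable from compound 3 to compound 4. Compound 4 is expected to give about 20000 nM, within a range from 3000 nM to 100000 nM, and it remains quite possible that the assay again reports only a limit for compound 4.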

Compound 4, concentration lethal to 50% of the cells: < 100000 nM
Compound 4: a limit, no number (the forecaster's own chance of this, stated with the estimate: 60%); the middle value does not contradict the limit.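

In this assay compound 4 gives < 100000 nM, a limit and not a number. Among the compounds shown here, no step from compound 3 to compound 4 can be read, because all the values share one limit: the limit of < 100000 nM in this assay, at which 4 of the 4 values shown sit. The compounds shown leave open whether 3,4-dimethoxyphenyl in place of 3,4-dichlorophenyl changes the read-out at all, and how the four compounds rank.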